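Methoxy to hydroxy in a two-point series

The source may hold more compounds than are shown below. What is called first, only, known or untested is meant among the compounds shown, and "the series" means these compounds.

For the measured compounds named here, in a functional assay on A549 cells (Homo sapiens) for inhibition, read by MTT assay, with a stated time of 48 h (a lower number here means a stronger inhibitor, a higher number a weaker inhibitor), compound 2 (`COc1ccc(NC(=O)/C=C/c2coc3cc(OC)ccc3c2=O)cc1`) gives 23000 nM as the only true number so far. Compound 1 (`O=C(/C=C/c1coc2cc(O)ccc2c1=O)NCc1ccccc1`) gives > 100000 nM in the same read-out, and this is a limit of the assay, not a number. Compound 2 therefore has nothing to be ranked against except that limit.

Compound 3 (`COc1ccc(NC(=O)/C=C/c2coc3cc(O)ccc3c2=O)cc1`) differs from compound 2 by hydrogen in place of methyl on an oxygen on an aromatic ring, the methoxy to hydroxy change (hydrogen in place of methyl on an oxygen on an aromatic ring). Going by the values given here, no measured pair isolates this change, so the size of the step in this assay remains a judgement. Compound 1 also carries a hydroxy group and stands at its limit of > 100000 nM as the only hint of direction. A modest loss is expected, with the step of a 2.2-fold higher number from compound 2 to compound 3 (0.34 log units; beyond the scatter) estimated to lean toward a weaker inhibitor. Compound 3 is estimated at 50000 nM with an expected range from 15000 nM to 100000 nM for now.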

Compound 3, half-maximal inhibitory concentration: 12800 nM
The estimate for compound 3 lay 3.9-fold (0.59 log units) above the measured number; the whole stated range lies above it.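

In this assay, the methoxy to hydroxy change now has a measured size, a 1.8-fold lower number from compound 2 to compound 3 (0.25 log units; within the scatter), so compound 2 and compound 3 cannot be told apart and hydrogen in place of methyl on this oxygen on an aromatic ring is tolerated in this pair. Compound 3 carries the same hydroxy group as compound 1, and an at least 7.8-fold lower number from compound 1 to compound 3 (0.89 log units; beyond the scatter) marks 4-methoxyphenyl in place of benzyl on the amide-type nitrogen as a change that matters in this read-out, so the hydroxy group alone does not tie a compound to the limit. That step is only a lower bound, since compound 1 stands at a limit and not at a number: the limit of > 100000 nM in this assay, at which 1 of the 3 values shown sits.

Still open, on these data alone, is whether a group such as an amine or a longer chain like ethoxy in this place on the aromatic ring would also leave the number within the scatter of compound 2 and compound 3. It is also unknown how an unsubstituted phenyl or a phenyl bearing a carboxylic acid on the amide-type nitrogen would compare with the 4-methoxyphenyl of compound 3.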